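This account rests on a few compounds, and the source may have more. Where it says the series, first, only, none or still open, it means among the compounds named here.

Compound 1 `[N-]=[N+]=N[C@@H]1C(n2ccc(=O)[nH]c2=O)[Se][C@H](CO)[C@H]1O` is the reference point of this short series. In a functional assay on PC-3 cells (Homo sapiens) for cytotoxicity, read by sulforhodamine B assay (a lower number here means a stronger inhibitor, a higher number a weaker inhibitor), compound 1 gives > 100000 nM, which is a limit of the assay and not a number. Compound 2 `[N-]=[N+]=N[C@@H]1C(n2cc(I)c(=O)[nH]c2=O)[Se][C@H](CO)[C@H]1O` carries iodo in place of hydrogen on an aromatic carbon of the shared core. In this assay compound 2 gives > 100000 nM, again a limit. The step that the two limits leave unreadable from compound 1 to compound 2 is therefore unreadable, since (the limit of > 100000 nM in this assay, at which 2 of the 2 values shown sit). Compound 1 thus stands only at a limit, with no numbered value in this assay anywhere in the series.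

Compound 3 `O=c1ccn(C2[Se][C@H](CO)[C@@H](O)[C@@H]2O)c(=O)[nH]1` differs from compound 1 by hydroxy in place of azido on a saturated ring carbon. Within the data shown here, the one measured step, a step that the two limits leave unreadable from compound 1 to compound 2, concerns a different part of the core and has no readable size, so no measured step bears on the present change. No direction can be drawn from the data. The working expectation is that compound 3 also sits at or near the limit in this assay, with the expected step being a step that the limit leaves unreadable from compound 1 to compound 3, nothing beyond the scatter. Compound 3 is estimated at 200000 nM, within 50000 nM to 1000000 nM.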

Compound 3, half-maximal inhibitory concentration: > 100000 nM
Compound 3 was reported as a limit; the forecaster's own chance of this, stated with the estimate: 85%; the middle value is on the limit's open side.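

Among these compounds, compound 3, like compound 1, stands only at a limit and not at a number, so the step between them cannot be read and no new step follows: the limit of > 100000 nM in this assay, at which 3 of the 3 values shown sit.

Still open, as far as these compounds go, is how azido and hydroxy on this saturated ring carbon compare in this assay once a numbered value exists for either compound.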